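Ring size at the thiocarbonyl: piperidine to pyrrolidine

The source may report more compounds than this note shows. Statements on the series, on what has been measured and on what is new or still open speak of the compounds shown alone.

Compound 3 `N/C(=N\NC(=S)N1CCCCC1)c1ccccn1` gives 38.6% in a functional assay on MCF7 cells (Homo sapiens) for cytotoxicity, read by MTT assay, with a stated time of 72 h, tested at 3 uM (a lower number here means less inhibition of growth, a higher number more inhibition of growth at the concentration tested), the lowest of the three numbers in hand. Compound 1 `N/C(=N\NC(=S)N1CCOCC1)c1ccccn1` gives 44.5%; the step of a number 5.9 percentage points lower from compound 1 to compound 3 (within the scatter) lies within the scatter. Compound 2 `N/C(=N\NC(=S)N1CCCC1)c1ccc(F)cn1` gives 52.6%, a number beyond the scatter above compound 3, but compound 2 also carries a different core, so its value does not isolate the ring change. Compound 4 `N/C(=N\NC(=S)N1CCCC1)c1ccccn1` is formed by pyrrolidin-1-yl in place of piperidin-1-yl on a thiocarbonyl carbon. Going by the values given here, the only single step at this position, from morpholin-4-yl to piperidin-1-yl, stayed within the scatter, so no step beyond the scatter is expected in this assay, though the value of compound 2 leaves room for a slightly higher number. Compound 4 is therefore estimated at 44%, between 30% and 58%, an expected step of a number 5.4 percentage points higher from compound 3 to compound 4 (within the scatter).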

Compound 4, percent growth inhibition at one concentration: 49.8%
The estimate for compound 4 lay 5.8 percentage points below the measured number, within the range that was stated.
By their numbers in this assay, from the lowest: compounds 3, 1, 4 and 2 (each within the scatter of the next, the first and the last beyond it).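

In this assay the group on the thiocarbonyl carbon gives its first step beyond the scatter: a number 11.2 percentage points higher from compound 3 to compound 4 (beyond the scatter) with pyrrolidin-1-yl in place of piperidin-1-yl. Morpholin-4-yl stands apart from neither ring, as a number 5.3 percentage points higher from compound 1 to compound 4 (within the scatter) also stays within the scatter, and the fluoro on the aromatic carbon can now be read alone, with a number 2.8 percentage points lower from compound 2 to compound 4 (within the scatter) likewise within the scatter. No measurement at hand accounts for the step from piperidin-1-yl to pyrrolidin-1-yl.

Open, from the compounds shown here alone, is how azetidin-1-yl, azepan-1-yl or an open-chain dimethylamino group on the thiocarbonyl carbon would fall in this order. Also open, going by these compounds, is whether chloro or methoxy in place of fluoro on the aromatic carbon would move the number beyond the scatter.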